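A few compounds are considered here, and "the series" means these few. Any claim that something is new, unique, unknown or untested is made for them only; others in the source may bear on it.

Compound 1 `CN1CCN(c2nc(N)c(C(=O)N=C(N)N)nc2Cl)CC1` gives 51% in an assay for inhibition of acid-sensing ion channel 3 (Homo sapiens), read by patch clamp, tested at 20 uM; on this read-out higher numbers stand for more inhibition at the one concentration tested (going by the name of the read-out) and lower numbers for less inhibition. Compound 2 `NC(N)=NC(=O)c1nc(Cl)c(Nc2ccccc2)nc1N` keeps the shared core but carries anilino in place of 4-methylpiperazin-1-yl on an aromatic carbon, and in this assay compound 2 gives 95%; the step of a number 44 percentage points higher from compound 1 to compound 2 (beyond the scatter) is large. Going by the values given here, of the two numbers measured so far, compound 2 holds the higher one, and its nearest neighbour, compound 1, sits well beyond the scatter below it. Compound 3 `NC(N)=NC(=O)c1nc(Cl)c(Nc2ccccn2)nc1N` has not yet been measured. It differs from compound 2 in one place: pyridin-2-yl in place of phenyl on a nitrogen on an aromatic ring. Among the compounds with values here, the only measured step, a number 44 percentage points higher from compound 1 to compound 2 (beyond the scatter), shows that exchanging the whole group on that aromatic carbon can move the number a great deal, but no measured step exchanges phenyl for pyridin-2-yl while keeping the amine nitrogen. The step of a number 10 percentage points lower from compound 2 to compound 3 (within the scatter) is therefore expected to be small, with no clear direction. Compound 3 is estimated at 85%, in a range from 62% to 98%.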

Compound 3, a percentage reported as inhibition, at one concentration (the size of the read-out at that concentration, not a potency): 25%
Compound 3: the middle estimate sits 60 percentage points above what was measured, outside the stated range (below it).
By their numbers in this assay, from the lowest: compound 3; then compound 1; then compound 2.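

In this assay, the step of a number 70 percentage points lower from compound 2 to compound 3 (beyond the scatter) shows that this position responds strongly even to a small edit: the ring on the amine nitrogen keeps its size and only gains a ring nitrogen. The earlier compounds shown here showed only the exchange of a whole group, whereas the step of a number 26 percentage points lower from compound 1 to compound 3 (beyond the scatter) shows that an aromatic ring on that amine nitrogen does not by itself raise the number over 4-methylpiperazin-1-yl, since anilino does and (pyridin-2-yl)amino does not. No measurement shown here explains why the two rings differ so sharply.

From the compounds shown here alone, it remains open whether pyridin-3-yl or pyridin-4-yl on the same nitrogen would lose as much as pyridin-2-yl. Going by these compounds, it is also open whether a saturated ring such as cyclohexyl would keep the number of the phenyl compound.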